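Trimming a Methoxy from an Inactive Chalcone-Pyrazole Series

A few compounds are considered here, and "the series" means these few. Any claim that something is new, unique, unknown or untested is made for them only; others in the source may bear on it.

Three compounds sharing one core were tested in a functional assay on NCI-H460 cells (Homo sapiens) for cytotoxicity, read by sulforhodamine B assay, with a stated time of 48 h, tested at 0.1 uM; a higher number here means a weaker effect of the compound at the concentration tested, a lower number a stronger effect. Compound 1 `COc1cc(-c2cc(/C=C/C(=O)c3ccc(N)cc3)[nH]n2)cc(OC)c1OC` gives 102%. Compound 2 `COc1cc(-c2cc(/C=C/C(=O)c3ccc(Cl)c(Cl)c3)[nH]n2)cc(OC)c1OC` gives 105%. Compound 3 `COc1ccc(C(=O)/C=C/c2cc(-c3cc(OC)c(OC)c(OC)c3)n[nH]2)cc1OC` gives 101%. Compound 3 sits within the scatter of both others: the steps of a number 1 percentage points lower from compound 1 to compound 3 (within the scatter) and a number 4 percentage points lower from compound 2 to compound 3 (within the scatter) are small, as is a number 3 percentage points higher from compound 1 to compound 2 (within the scatter), so none of the three shows a measurable effect at this concentration and none can be ranked against another.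

Compound 4 `COc1ccc(C(=O)/C=C/c2cc(-c3cc(OC)c(OC)c(OC)c3)n[nH]2)cc1` differs from compound 3 by hydrogen in place of methoxy on an aromatic carbon. All three measured steps exchanged groups on the same aryl ring attached to the carbonyl carbon, and every one stayed within the scatter, which bears directly on this smaller change at the same ring. The expectation for no change at the digits printed from compound 3 to compound 4 (within the scatter) is therefore no step beyond the scatter. Compound 4 is estimated to give 101% in this assay, within a range from 90% to 112%.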

Compound 4, a percentage reported as activity, at one concentration (the size of the read-out at that concentration, not a potency): 102%
The estimate for compound 4 lay 1 percentage points below the measured number; the measured number falls inside the stated range.
By their numbers in this assay, from the lowest: compounds 3, 1, 4 and 2 (each within the scatter of the next).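

In this assay, cutting 3,4-dimethoxyphenyl back to 4-methoxyphenyl gives a number 1 percentage points higher from compound 3 to compound 4 (within the scatter), so the methoxy that is ortho to a methoxy group and meta to a large group can be replaced by hydrogen with no readable change at this concentration. The 4-methoxyphenyl compound also stays level with the other aryl groups, with a number 3 percentage points lower from compound 2 to compound 4 (within the scatter) and no change at the digits printed from compound 1 to compound 4 (within the scatter), which extends the flat picture at this ring to a fourth group. No supporting measurement is available to interpret this result.

Since all four compounds lie within the scatter of one another at a single concentration, the data cannot show whether this methoxy matters under conditions where the series has an effect. On these data alone, whether a carboxylic acid or a longer chain such as butoxy on this ring would move the number remains open.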